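The compounds below may be only part of what the source reports. "The series", "measured", "known", "first", "only" and "open" are said of these compounds alone.

Measured so far in a functional assay on A549 cells (Homo sapiens) for antiproliferative activity, read by MTT assay, with a stated time of 72 h; on this read-out higher numbers stand for weaker inhibition and lower numbers for stronger inhibition:
- compound 3, `CN1CCN(c2ccc(Nc3ncc4nc(Nc5ccccc5)n([C@@H]5CCN(S(=O)(=O)C6CC6)C5)c4n3)cc2)CC1`: 2910 nM
- compound 1, `CN1CCN(c2ccc(Nc3ncc4nc(Nc5ccccc5)n([C@H]5CCNC5)c4n3)cc2)CC1`: "not determined" (no result reported)
- compound 2, `CN1CCN(c2ccc(Nc3ncc4nc(Nc5ccc(F)cc5)n([C@H]5CCN(C(=O)CO)C5)c4n3)cc2)CC1`: "not determined" (no result reported)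

Compound 2 stands without a single number in this assay; compound 1 is a further entry without a single number, so only compound 3 carries a value, and nothing can be said of how compound 2 compares with it. Compound 3 shares the core of compound 2 but differs from it in more than one place, so it gives only a rough frame.

The step to compound 4, `CN1CCN(c2ccc(Nc3ncc4nc(Nc5ccc(F)cc5)n([C@H]5CCN(S(=O)(=O)C6CC6)C5)c4n3)cc2)CC1`, is a single change from compound 2: cyclopropylsulfonyl in place of (hydroxymethyl)carbonyl on an amine nitrogen in a ring. Among the compounds with values here, no measured pair shows this change, so its size in this assay is unknown; no direction is expected beyond the scatter, and the one value available for the series, from compound 3, is the only anchor. Compound 4 is therefore expected to land near that anchor, at 2500 nM, within a range of 700 nM to 9000 nM.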

Compound 4, half-maximal inhibitory concentration: 150 nM
Compound 4: the middle estimate sits 17-fold (1.22 log units) above what was measured; measured number outside the range, below it.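

With compound 2 carrying no single number in this assay, the step from compound 2 to compound 4 cannot be read. The compounds shown leave open what cyclopropylsulfonyl in place of (hydroxymethyl)carbonyl does to this read-out. No evidence at hand bears on the result.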